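The source may hold more compounds than are shown below. What is called first, only, known or untested is meant among the compounds shown, and "the series" means these compounds.

In a functional assay on PC-3 cells (Homo sapiens) for antiproliferative activity, read by sulforhodamine B assay, with a stated time of 96 h (a higher number here means a weaker inhibitor, a lower number a stronger inhibitor), compound 1 (`CN(C)c1ccc2c(c1)OC(N)=C(C#N)C2c1cccc2c(F)cccc12`) gives 420 nM and compound 2 (`COc1ccc(C2C(C#N)=C(N)Oc3cc(N(C)C)ccc32)c2ccccc12`) gives 430 nM, so these two values lie within the usual scatter of each other. Compound 3 (`CN(C)c1ccc2c(c1)OC(N)=C(C#N)C2c1ccc(F)c2ccccc12`) has not yet been measured. It differs from compound 2 by a single swap, fluoro in place of methoxy on an aromatic carbon. Among the compounds with values here, no measured pair shows this swap on its own, so the evidence for any prediction is thin. Compound 1, which also carries a fluoro, gives 420 nM, and this offers no reason to expect a large shift in this assay. The expected change, a 1.2-fold lower number from compound 2 to compound 3 (0.09 log units; within the scatter), is therefore none beyond the scatter, with no firm direction. The estimate for compound 3 is 350 nM, with an expected range from 130 nM to 900 nM.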

Compound 3, half-maximal inhibitory concentration: 640 nM
Compound 3: middle estimate off by 1.8-fold (0.26 log units), on the low side; the range from low to high includes it.
By their numbers in this assay, from the lowest: compounds 1, 2 and 3 (each within the scatter of the next).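

In this assay, within the data shown here, the swap of fluoro in place of methoxy on an aromatic carbon, para to a large group, gives a 1.5-fold higher number from compound 2 to compound 3 (0.17 log units; within the scatter) and is the first direct reading of a change at this position. Here, a methoxy of 2 heavy atoms and a hydrogen-bond acceptor gives way to a fluoro of 1 heavy atom and no acceptor, yet the step stays inside the normal noise of the assay, so this one pair does not separate the two groups. No supporting data bear on this result, so it offers no explanation for it.

The compounds shown leave open whether other groups at this position would also stay within the scatter. An amine, a carboxylic acid or a longer chain such as ethoxy could test how far this position accepts change.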